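The source may report more compounds than this note shows. Statements on the series, on what has been measured and on what is new or still open speak of the compounds shown alone.

Compound 1 `N=C(NCc1ccccc1)[C@@H]1CCC(=O)N1Cc1ccccc1`: 20.7%
Compound 2 `N=C(NCc1ccc(O)cc1)[C@@H]1CCC(=O)N1Cc1ccccc1`: 37.6%
Compound 3 `COc1ccc(CNC(=N)[C@@H]2CCC(=O)N2Cc2ccccc2)cc1`: 19.5%

In a functional assay on SH-SY5Y cells (Homo sapiens) for cytotoxicity, read by MTT assay, with stated times of 8 h, 30 min and 12 h, tested at 5 uM (a lower number here means a weaker effect, a higher number a stronger effect of the compound at the concentration tested), compound 3 stands within the scatter of compound 1, as a number 1.2 percentage points lower from compound 1 to compound 3 (within the scatter) shows, while its gap to compound 2 is beyond the scatter: a number 18.1 percentage points lower from compound 2 to compound 3 (beyond the scatter). Compound 4 `COc1ccc(CNC(=N)[C@@H]2CCC(=O)N2Cc2ccc(C)cc2)cc1` differs from compound 3 by methyl in place of hydrogen on an aromatic carbon, a change on the other benzyl group, the one on the ring nitrogen of the shared core. For the measured compounds named here, no measured step touches that group, so the only guide is that a small change on an aromatic carbon, a number 1.2 percentage points lower from compound 1 to compound 3 (within the scatter), stayed within the scatter, whereas a number 16.9 percentage points higher from compound 1 to compound 2 (beyond the scatter) was modest. On this basis no step beyond the scatter is expected for compound 4, estimated at 20% (range 9% to 33%), meaning an expected step of a number 0.5 percentage points higher from compound 3 to compound 4 (within the scatter).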

Compound 4, a percentage reported as activity, at one concentration (the size of the read-out at that concentration, not a potency): 29.5%
Estimate against measurement, compound 4: 9.5 percentage points below; low and high end bracket the measured number.
By their numbers in this assay, from the lowest: compounds 3, 1, 4 and 2 (each within the scatter of the next, the first and the last beyond it).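

For the compounds shown here, this is the first measured step on the benzyl group on the ring nitrogen of the shared core. Going from benzyl to 4-methylbenzyl gives a number 10 percentage points higher from compound 3 to compound 4 (within the scatter) in this assay, so a methyl at this place leaves the read-out within the usual scatter. Nothing shown explains this result.

From the compounds shown here alone, it remains open whether a larger change at this place, such as an amine or a carboxylic acid, would give a step beyond the scatter. Going by these compounds, the same methyl also remains untested alongside the hydroxy group of compound 2.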